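Adding a Methoxy Group: From Compound 1 to Compound 4

The source may hold more compounds than are shown below. What is called first, only, known or untested is meant among the compounds shown, and "the series" means these compounds.

Measured compounds:
compound 1, `COc1ccc(-c2cc(/C=C/C(=O)c3ccc(N)cc3)[nH]n2)cc1`, 84%
compound 2, `COc1ccc(C(=O)/C=C/c2cc(-c3cc(OC)c(OC)c(OC)c3)n[nH]2)cc1OC`, 84%
compound 3, `COc1ccc(C(=O)/C=C/c2cc(-c3cc(OC)c(OC)c(OC)c3)n[nH]2)cc1`, 86%

In a functional assay on A549 cells (Homo sapiens) for cytotoxicity, read by sulforhodamine B assay, with a stated time of 48 h, tested at 1 uM (a lower number here means a stronger effect, a higher number a weaker effect of the compound at the concentration tested), compound 1 gives 84%, which is level with compound 2 at the digits shown and together with it the lowest of the three numbers; compound 3 lies a little higher, but every gap here is within the scatter. Compound 4, `COc1ccc(-c2cc(/C=C/C(=O)c3ccc(N)cc3)[nH]n2)cc1OC`, is not yet measured. It differs from compound 1 by methoxy in place of hydrogen on an aromatic carbon. Going by the values given here, the one measured step of this kind, a methoxy exchanged for a hydrogen on an aromatic carbon, is a number 2 percentage points higher from compound 2 to compound 3 (within the scatter). That step stayed within the scatter, so no step beyond the scatter is expected in this assay from compound 1 to compound 4, the expected change being no change at the digits printed from compound 1 to compound 4 (within the scatter). Compound 4 is therefore estimated at 84%, with a range from 74% to 94%.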

Compound 4, a percentage reported as activity, at one concentration (the size of the read-out at that concentration, not a potency): 89%
Estimate against measurement, compound 4: 5 percentage points below, within the range that was stated.
By their numbers in this assay, from the lowest: compounds 1, 2, 3 and 4 (each within the scatter of the next).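

On a second core, methoxy in place of hydrogen on an aromatic carbon, ortho to a methoxy group, gives in this assay a number 5 percentage points higher from compound 1 to compound 4 (within the scatter). The change can now be read on two different cores, and on neither does it move the number beyond the scatter: the same change on two cores in this assay, a number 2 percentage points higher (within the scatter) from compound 2 to compound 3 and a number 5 percentage points lower (within the scatter) from compound 4 to compound 1, 7 percentage points apart, within the scatter of two such steps

From the compounds shown here alone, whether an ethoxy group, a hydroxyl group or a fluorine atom in this place would move the number beyond the scatter stays open. So does the question of whether the methoxy change would matter at any other concentration.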